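The compounds below may be only part of what the source reports. "The series", "measured", "known", "first", "only" and "open" are said of these compounds alone.

Of the compounds shown here, three built on a shared core have so far been measured in a functional assay on Maver1 cells (Homo sapiens) for inhibition, read by luminescence and CellTiter-Glo, with a stated time of 72 h; a lower number here means a stronger inhibitor, a higher number a weaker inhibitor. Compound 1 `O=C(CCl)N1CCCC(n2nc(-c3ccc(Oc4ccccc4)cc3)cc2CO)C1` gives 1100 nM in this assay, the second highest of the three numbers. Compound 2 `O=C(CCl)Nc1cccc(Cn2nc(-c3ccc(Oc4ccccc4)cc3)cc2CO)c1` gives 400 nM, a lower number than compound 1 by a gap beyond the usual scatter, so compound 2 is the stronger inhibitor of the two. Compound 3 `C=CC(=O)Nc1cccc(Cn2nc(-c3ccc(Oc4ccccc4)cc3)cc2C(=O)OCC)c1` gives 8600 nM, a higher number than compound 1 by a gap that is also beyond the scatter, so compound 3 is the weaker inhibitor of that pair.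

Compound 4 `C/C=C/C(=O)N1CCCC(n2nc(-c3ccc(Oc4ccccc4)cc3)cc2CO)C1` has not yet been measured. It differs from compound 1 in one place: prop-1-en-1-yl in place of chloromethyl on a carbonyl carbon. Within the data shown here, no measured pair shows this exact change on its own; compound 3 carries a related carbon double bond on its carbonyl but differs from the others in a second place as well, so its high number cannot be tied to one change.

Compound 4 is expected to give about 3500 nM in this assay, with a plausible range from 1000 nM to 12000 nM. That estimate means an expected step of a 3.2-fold higher number from compound 1 to compound 4 (0.50 log units; beyond the scatter) toward a higher number, that is toward weaker inhibition, and beyond the scatter.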

Compound 4, half-maximal inhibitory concentration: > 60000 nM
Compound 4: only a limit was reported; the forecaster's own chance of this, stated with the estimate: 10%; at least 17-fold (1.23 log units) between middle value and limit.
By their numbers in this assay, from the lowest: compound 2; then compound 1; then compound 3. At a limit, above all of these: compound 4.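

On a carbonyl carbon whose other neighbour is an amide-type nitrogen in a ring, the group attached turns out to matter a great deal: putting prop-1-en-1-yl in place of chloromethyl gives an at least 54-fold higher number from compound 1 to compound 4 (1.73 log units; beyond the scatter) in this assay. On these data alone, the reading for compound 4 is a limit of the assay and not a number, so the true size of this step stays unknown on the high side: the limit of > 60000 nM in this assay, at which 1 of the 4 values shown sits. Compound 3 also carries a carbon double bond on its carbonyl, but it differs from the others in a second place, whereas this pair differs in one place only, so here the loss of inhibition can be tied to a single change.

This one pair cannot tell whether the loss goes with the departure of the chlorine or with the arrival of the prop-1-en-1-yl chain, and a plain vinyl group or a longer chain ending in an amine on the same carbonyl would help to separate the two. As far as these compounds go, it also remains open whether the same exchange would cost as much on the core of compound 2.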